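Compound 3 to Compound 4: Replacing the 4-Fluorophenyl Group

The compounds below may be only part of what the source reports. "The series", "measured", "known", "first", "only" and "open" are said of these compounds alone.

In an ADME assay on J774.A1 cells (Mus musculus) for cytotoxicity, read by MTT assay, with a stated time of 48 h (a lower number here means that less compound is tolerated, a higher number that more compound is tolerated), compound 3 (`O=C(NCc1ccc(F)cc1)c1c([N+](=O)[O-])noc1-c1ccc(Cl)cc1Cl`) gives 86400 nM. Compound 2 (`O=C(NCc1ccc(F)cc1)c1c([N+](=O)[O-])noc1-c1ccc(Cl)cc1`) gives 91900 nM, and the chloro exchange linking the pair, a 1.1-fold lower number from compound 2 to compound 3 (0.03 log units; within the scatter), stays within the scatter. Compound 1 (`COC(=O)c1c([N+](=O)[O-])noc1-c1ccc(Cl)cc1Cl`) gives 19700 nM, so compound 3 stands clearly apart from it, with a 4.4-fold higher number from compound 1 to compound 3 (0.64 log units; beyond the scatter) on exchanging methoxy for (4-fluorobenzyl)amino on a carbonyl carbon.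

Compound 4 (`COc1ccc(CNC(=O)c2c([N+](=O)[O-])noc2-c2ccc(Cl)cc2Cl)cc1OC`) carries 3,4-dimethoxyphenyl in place of 4-fluorophenyl on a saturated chain carbon bound to an amide-type nitrogen. Among the compounds with values here, no measured step changes this group, so the evidence is indirect. Compound 4 keeps the amide that accompanies a 4.4-fold higher number from compound 1 to compound 3 (0.64 log units; beyond the scatter) and the chloro substituent whose step, a 1.1-fold lower number from compound 2 to compound 3 (0.03 log units; within the scatter), lies within the scatter. The expected change is a 1.2-fold lower number from compound 3 to compound 4 (0.09 log units; within the scatter), which is estimated to be no step beyond the scatter. For compound 4 the estimated value is 70000 nM, with an expected range of 30000 nM to 150000 nM.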

Compound 4, half-maximal cytotoxic concentration: 81800 nM
Compound 4: middle estimate off by 1.2-fold (0.07 log units), on the low side; the range from low to high includes it.
By their numbers in this assay, from the lowest: compound 1; then compounds 4, 3 and 2 (each within the scatter of the next).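

In this assay, within the data shown here, the exchange of 4-fluorophenyl for 3,4-dimethoxyphenyl gives a 1.1-fold lower number from compound 3 to compound 4 (0.02 log units; within the scatter), the first measured step at this position on a saturated chain carbon bound to an amide-type nitrogen. The entering group has more heavy atoms and two hydrogen-bond acceptors, whereas the leaving group has none, yet this difference in composition comes with no change beyond the scatter. No measured evidence bears on this result.

From the compounds shown here alone, whether an amine or a carboxylic acid on this aromatic ring, or a longer chain in place of the saturated chain carbon, would also stay within the scatter remains open. Going by these compounds, it is also open whether 3,4-dimethoxyphenyl would give a similar result on the core of compound 2.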